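From 3-cyanophenyl to 2-methylphenyl at a limit

The source may report more compounds than this note shows. Statements on the series, on what has been measured and on what is new or still open speak of the compounds shown alone.

In a functional assay on HEK293 cells (Homo sapiens) for cytotoxicity (a higher number here means that more compound is tolerated, a lower number that less compound is tolerated), compound 3 `COc1ccc([C@H]2CC(=O)N(c3cccc(C#N)c3)C2)cc1OC1CCCC1` gives > 10000 nM as a limit and not a number. Compound 1 `COc1ccc([C@H]2CC(=O)N(Cc3cccc([N+](=O)[O-])c3)C2)cc1OC1CCCC1` gives > 10000 nM as a limit too. Compound 2 `COc1ccc([C@H]2CC(=O)N(c3ccccc3N)C2)cc1OC1CCCC1` likewise gives > 10000 nM as a limit. The series thus stands at the limit of > 10000 nM in this assay, at which 3 of the 3 values shown sit, with nothing else to read. Compound 4 `COc1ccc([C@H]2CC(=O)N(c3ccccc3C)C2)cc1OC1CCCC1` has 2-methylphenyl in place of 3-cyanophenyl on an amide-type nitrogen in a ring. Three measured steps at that nitrogen bear on it: a step that the two limits leave unreadable from compound 1 to compound 2 and a step that the two limits leave unreadable from compound 1 to compound 3 and a step that the two limits leave unreadable from compound 2 to compound 3 give no readable size. No step beyond the scatter is therefore expected in this assay and no direction can be expected either. The expected step that the limit leaves unreadable from compound 3 to compound 4 is only an estimate. For compound 4 the estimated value is 15000 nM with a range from 6000 nM to 40000 nM expected.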

Compound 4, half-maximal cytotoxic concentration: > 10000 nM
Compound 4: no number, only a limit; the forecaster's own chance of this, stated with the estimate: 88%; the middle value does not contradict the limit.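

In this assay, among these compounds, compound 4 gives > 10000 nM, a limit and not a number, so no step to compound 4 from compound 1, compound 2 or compound 3 can be read. The compounds shown leave open how any group on the amide-type nitrogen in a ring changes the tolerated concentration, since all of them stand at one place: the limit of > 10000 nM in this assay, at which 4 of the 4 values shown sit.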